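The compounds below may be only part of what the source reports. "The series", "measured", "known", "first", "only" and "open" are said of these compounds alone.

Measured compounds:
compound 1 `O=C(O)CC1CC(CNC(=O)CCCNc2nccs2)=CCc2ccccc21` gives 40 nM in a functional assay on IGROV-1 cells (Homo sapiens) for inhibition; on this read-out lower numbers stand for stronger inhibition and higher numbers for weaker inhibition;
compound 2 `O=C(O)CC1CC(CNC(=O)CCNCc2ccccn2)=CCc2ccccc21` gives 2700 nM in this assay;
compound 3 `O=C(O)CC1CC(CNC(=O)CCCNC2=NCCCN2)=CCc2ccccc21` gives 2.7 nM in this assay.

Among these three, compound 1 holds the middle position: compound 3 sits well below it, as shown by a 15-fold lower number from compound 1 to compound 3 (1.17 log units; beyond the scatter), while compound 2 sits far above it, as shown by a 68-fold higher number from compound 1 to compound 2 (1.83 log units; beyond the scatter).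

Compound 4 `CN(CCCC(=O)NCC1=CCc2ccccc2C(CC(=O)O)C1)c1ccccn1` has not yet been measured. It differs from compound 1 in one place: methyl(pyridin-2-yl)amino in place of (1,3-thiazol-2-yl)amino on a saturated chain carbon, three bonds along the chain from a carbonyl carbon. The chain between the carbonyl and the ring keeps the length it has in compound 1, but the ring and the nitrogen that carries it change, and the hydrogen-bond donor is lost.

Among the compounds with values here, two measured steps bear on this. Moving from compound 1 to a pyridine-bearing compound gave a 68-fold higher number from compound 1 to compound 2 (1.83 log units; beyond the scatter), and replacing that pyridine-bearing group with the cyclic group of compound 3 gave a 1000-fold lower number from compound 2 to compound 3 (3.00 log units; beyond the scatter). Both point the same way: the pyridine-bearing groups in this small set go with weaker inhibition. A step upward, beyond the scatter, is therefore expected for compound 4, though probably smaller than the step to compound 2.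

Compound 4 is estimated to give 500 nM, within a range of 120 nM to 2500 nM, which would mean an expected step of a 13-fold higher number from compound 1 to compound 4 (1.10 log units; beyond the scatter).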

Compound 4, half-maximal inhibitory concentration: 2030 nM
For compound 4 the middle estimate is 4.1-fold (0.61 log units) below the measured one; measured number inside the range.
By their numbers in this assay, from the lowest: compound 3; then compound 1; then compounds 4 and 2 (each within the scatter of the next).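

In this assay, methyl(pyridin-2-yl)amino on this saturated chain carbon is a poor replacement: the swap from (1,3-thiazol-2-yl)amino gives a 51-fold higher number from compound 1 to compound 4 (1.71 log units; beyond the scatter) and the swap from the six-membered non-aromatic ring group gives a 750-fold higher number from compound 3 to compound 4 (2.88 log units; beyond the scatter) in the same direction. The new group matches the other pyridine-bearing group, with a 1.3-fold lower number from compound 2 to compound 4 (0.12 log units; within the scatter) for the change from ((pyridin-2-yl)methyl)amino, so the way the pyridin-2-yl ring is attached to the chain makes no readable difference here. Compound 4 also keeps the chain length of compound 1, so among these four compounds the high number of a pyridine-bearing compound does not depend on a change in that length, and neither pyridine-bearing compound goes against this.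

From the compounds shown here alone, the step from compound 1 changes the ring, the added methyl and the hydrogen-bond donor count together, so the share of each stays unknown; a (pyridin-2-yl)amino group or a methyl(1,3-thiazol-2-yl)amino group on the same chain would separate them. Nothing measured here says why these groups give such different numbers.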